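Working notes: methyl to chloro in the sulfonamide series

This account rests on a few compounds, and the source may have more. Where it says the series, first, only, none or still open, it means among the compounds named here.

Measured in a functional assay on PC-3 cells (Mus musculus) for cytotoxicity against PC-3 (Homo sapiens); a higher number here means a weaker inhibitor, a lower number a stronger inhibitor:
- compound 1 `CCCN(CCC)c1c([N+](=O)[O-])cc(S(=O)(=O)Nc2ccc(C)cc2)cc1[N+](=O)[O-]`: 21000 nM
- compound 2 `CCCN(CCC)c1c([N+](=O)[O-])cc(S(=O)(=O)Nc2cccc(C)c2)cc1[N+](=O)[O-]`: 25000 nM

Compound 2 lies within the scatter of compound 1, so the two values cannot be ranked. Compound 3 `CCCN(CCC)c1c([N+](=O)[O-])cc(S(=O)(=O)Nc2cccc(Cl)c2)cc1[N+](=O)[O-]` has chloro in place of methyl on an aromatic carbon, meta to a large group: chloro in place of methyl on an aromatic carbon. Among the measured compounds shown here, only one measured step bears on this change, a 1.2-fold higher number from compound 1 to compound 2 (0.08 log units; within the scatter), and it stays within the scatter. That step moves the methyl and brings in no chloro, so it offers only weak guidance. For the measured compounds named here, no measured compound carries chloro. The starting point is therefore compound 2 at 25000 nM, and no step beyond the scatter is expected in this assay, in either direction. The expected step is a 1.1-fold lower number from compound 2 to compound 3 (0.06 log units; within the scatter). Compound 3 is estimated at 22000 nM, with an expected range of 10000 nM to 50000 nM.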

Compound 3, half-maximal inhibitory concentration: 18000 nM
Estimate against measurement, compound 3: 1.2-fold (0.09 log units) above, within the range that was stated.
By their numbers in this assay, from the lowest: compounds 3, 1 and 2 (each within the scatter of the next).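

In this assay, chloro in place of methyl on an aromatic carbon, meta to a large group, gives a 1.4-fold lower number from compound 2 to compound 3 (0.14 log units; within the scatter), so the first chloro compound cannot be separated from its methyl counterpart. With 3-chlorophenyl in place of 4-methylphenyl on the sulfonamide nitrogen, the result is a 1.2-fold lower number from compound 1 to compound 3 (0.07 log units; within the scatter), so this two-part difference also gives no separation, and all three compounds lie within the scatter of one another. No independent measurement bears on this result.

Still open, as far as these compounds go, is whether any group at this position can move the number beyond the scatter; an amine or a carboxylic acid in place of the chloro would test this. Also open, from the compounds shown here alone, is whether a longer chain at this position would behave any differently from methyl and chloro.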